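This account rests on a few compounds, and the source may have more. Where it says the series, first, only, none or still open, it means among the compounds named here.

Compound 2 `COc1cc(NC(=O)Nc2cc(Nc3ccc(C)c(F)c3)ncn2)cc(OC)c1` was tested in a functional assay on PC-9 cells (Homo sapiens) for inhibition, read by MTT assay, with a stated time of 48 h, tested at 10 uM (on this read-out lower numbers stand for less inhibition and higher numbers for more inhibition at the one concentration tested (going by the name of the read-out)), where compound 2 gives 77.5%. Going by the values given here, its only measured companion is compound 1 `COc1cc(Nc2cc(NC(=O)Nc3c(Cl)cccc3Cl)ncn2)cc(OC)c1`, which in this assay gives 90%; compound 2 thus stands lowest of the two numbers, and the gap to compound 1 lies beyond the usual scatter. Compound 3 `COc1cc(NC(=O)Nc2cc(Nc3cc(F)ccc3OC)ncn2)cc(OC)c1` has not yet been measured. It differs from compound 2 in one place: 5-fluoro-2-methoxyphenyl in place of 3-fluoro-4-methylphenyl on a nitrogen on an aromatic ring. Among the compounds with values here, no pair of measured compounds shows this kind of change, so there is no measured step to lean on. The present author expects a step from compound 2 to compound 3 of about a number 5.5 percentage points lower from compound 2 to compound 3 (within the scatter), a small downward shift that may well stay within the scatter. Compound 3 is therefore estimated at 72%, with a range from 52% to 90%.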

Compound 3, a percentage reported as inhibition, at one concentration (the size of the read-out at that concentration, not a potency): 59.5%
Estimate against measurement, compound 3: 12.5 percentage points above; the range from low to high includes it.
By their numbers in this assay, from the lowest: compound 3; then compound 2; then compound 1.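

In this assay, going by these compounds alone, the group on this nitrogen proves to matter: 5-fluoro-2-methoxyphenyl in place of 3-fluoro-4-methylphenyl gives a number 18 percentage points lower from compound 2 to compound 3 (beyond the scatter), a step the earlier compounds could not show, as they differ in more than one place. The entering group counts one hydrogen-bond acceptor and the leaving group none, but the two groups also differ in other ways, so the step cannot be tied to any single feature. Nothing at hand bears on the reason for this fall.

The compounds shown leave open whether the fall belongs to the methoxy group, to the loss of the methyl group or to the changed place of the fluorine. Going by these compounds, it also stays open what a plain phenyl or a morpholine-bearing phenyl on this nitrogen would give in this assay.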